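From Methyl to Pyrimidin-2-yl on the Ring Nitrogen

A few compounds are considered here, and "the series" means these few. Any claim that something is new, unique, unknown or untested is made for them only; others in the source may bear on it.

Compound 1 `N#Cc1ccc(Nc2nc(Oc3ccnc4ccccc34)nc(N3CCN(C(c4ccccc4)c4ccc(Cl)cc4)CC3)n2)cc1C(F)(F)F` sits at a limit in a functional assay on DU-145 cells (Homo sapiens) for cytotoxicity, read by sulforhodamine B assay, with a stated time of 48 h (a higher number here means a weaker inhibitor of growth, a lower number a stronger inhibitor of growth), giving > 100000 nM.
Compound 2 `CN1CCN(c2nc(Nc3ccc(C#N)c(C(F)(F)F)c3)nc(Oc3ccnc4ccccc34)n2)CC1` gives 51200 nM in this assay.
Compound 3 `N#Cc1ccc(Nc2nc(Oc3ccnc4ccccc34)nc(N3CCN(C(c4ccccc4)c4ccccc4)CC3)n2)cc1C(F)(F)F` also sits at a limit, giving > 100000 nM.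

For the measured compounds named here, compound 2 thus holds the only number of the three; the other two values rest at the limit of > 100000 nM in this assay, at which 2 of the 3 values shown sit. Going by the values given here, the one measured step, a step that the two limits leave unreadable from compound 1 to compound 3, cannot be read because both ends are limits, so nothing measured bears on the change now at hand. Compound 4 `N#Cc1ccc(Nc2nc(Oc3ccnc4ccccc34)nc(N3CCN(c4ncccn4)CC3)n2)cc1C(F)(F)F` differs from compound 2 by pyrimidin-2-yl in place of methyl on an amine nitrogen in a ring. With no readable step to lean on, the expectation for compound 4 is an estimate of 90000 nM, ranging from 30000 nM to 300000 nM. The step that estimate implies, a 1.8-fold higher number from compound 2 to compound 4 (0.24 log units; within the scatter), is expected to be toward weaker growth inhibition, with a real chance of reaching the limit.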

Compound 4, concentration for 50% growth inhibition: 85200 nM
Beside the measured number, compound 4's estimate is 1.1-fold (0.02 log units) above it, within the range that was stated.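

For the compounds shown here, at the amine nitrogen in the ring, compound 2 and compound 4 provide the first readable step in this assay: a 1.7-fold higher number from compound 2 to compound 4 (0.22 log units; within the scatter). A methyl of one carbon and a pyrimidin-2-yl of six heavy atoms, with its six-membered aromatic ring, therefore cannot be told apart here. Compound 4 also keeps a readable number rather than joining the values at the limit: the limit of > 100000 nM in this assay, at which 2 of the 4 values shown sit.

This rests on a single pair in a single assay. On these data alone, whether a hydrogen, a carboxylic acid or a longer alkyl chain on this nitrogen would give a step beyond the scatter stays open.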